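Pyrazoline series: chloro in place of fluoro on aryl ring

The compounds below may be only part of what the source reports. "The series", "measured", "known", "first", "only" and "open" are said of these compounds alone.

Working notes on a set of compounds sharing one core, examined in a functional assay on A549 cells (Homo sapiens) for cytotoxicity, read by MTT assay, with a stated time of 72 h; on this read-out higher numbers stand for weaker inhibition and lower numbers for stronger inhibition. Compound 1 `CNC(=O)c1cc(Oc2ccc(C3=NNC(c4ccc(Cl)cc4Cl)C3)cc2)ccn1` gives 6930 nM in this assay. Compound 2 `CNC(=O)c1cc(Oc2ccc(C3=NNC(c4ccc(F)cc4Cl)C3)cc2)ccn1` gives 13700 nM in this assay. Compound 3 `CNC(=O)c1cc(Oc2ccc(C3=NN(C(N)=S)C(c4ccc(F)cc4)C3)cc2)ccn1` gives 19400 nM in this assay; compound 3 holds the highest of the three numbers, with compound 2 nearest to it within the scatter and compound 1 furthest from it beyond the scatter. The difference between the core of compound 3 and the core of compound 2 is not broken down here.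

Among the measured compounds shown here, the one measured pair that differs in a single place is compound 2 and compound 1. The change is chloro in place of fluoro on an aromatic carbon and it made a 2.0-fold lower number from compound 2 to compound 1 (0.30 log units; within the scatter).

Compound 4 `CNC(=O)c1cc(Oc2ccc(C3=NN(C(N)=S)C(c4ccc(Cl)cc4)C3)cc2)ccn1` has not been measured in this assay. It differs from compound 3 by chloro in place of fluoro on an aromatic carbon. For the measured compounds named here, this is the same kind of change as the one from compound 2 to compound 1, not the same: in that earlier pair the place is also meta to a chloro group (1 heavy atom), whereas in compound 3 and compound 4 no such neighbouring group is present.

Going by the values given here, compound 4 is expected to show a 1.6-fold lower number from compound 3 to compound 4 (0.21 log units; within the scatter), a step of about the size seen in a 2.0-fold lower number from compound 2 to compound 1 (0.30 log units; within the scatter), which is the only measured instance of this kind of change. Compound 4 is estimated at 12000 nM, with the expected range running from 5000 nM to 30000 nM.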

Compound 4, half-maximal inhibitory concentration: > 50000 nM
Compound 4: only a limit was reported; the forecaster's own chance of this, stated with the estimate: 10%; middle value at least 4.1-fold (0.61 log units) away from the limit.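

In this assay, chloro in place of fluoro gives an at least 2.5-fold higher number from compound 3 to compound 4 (0.41 log units; beyond the scatter), whereas on the other core the same kind of change gave a 2.0-fold lower number from compound 2 to compound 1 (0.30 log units; within the scatter). The change therefore does not carry over from one core to the other in this series with the same direction or size: the same change on two cores in this assay, a 2.0-fold lower number (0.30 log units; within the scatter) from compound 2 to compound 1 and an at least 2.5-fold higher number (0.41 log units; beyond the scatter) from compound 3 to compound 4, at least 5.0-fold (0.70 log units) apart, beyond the scatter of two such steps. Going by these compounds, compound 4 gives > 50000 nM, which is a limit of the assay and not a number, so the size of the step stays unknown, and one pair per core does not show whether the gap follows the difference between the cores or the further chloro group present in compound 1 and compound 2: the limit of > 50000 nM in this assay, at which 1 of the 4 values shown sits.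

The compounds shown leave open how a methyl, a methoxy or a nitrile in place of the halogen would read out on either core, as only fluoro and chloro occur at this place. They also leave open whether the contrast between the two cores would persist on a 4-chlorophenyl or 4-fluorophenyl pair without the further chloro group.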